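The compounds below may be only part of what the source reports. "The series", "measured", "known", "first", "only" and "open" are said of these compounds alone.

The measured compounds and their values in a functional assay on MCF7 cells (Homo sapiens) for cytotoxicity, read by MTT assay, with a stated time of 72 h; on this read-out lower numbers stand for stronger inhibition and higher numbers for weaker inhibition:

compound 1, `CCOC(=O)c1c(C)oc2ncnc(Nc3ccc(OCc4ccc(C)cc4)cc3)c12`, gives > 1000000 nM, a limit of the assay and not a number;
compound 2, `CCOC(=O)c1c(C)oc2ncnc(Nc3ccc(OCc4ccccc4)cc3)c12`, gives > 1000000 nM, likewise a limit of the assay;
compound 3, `Cc1cccc(Nc2ncnc3oc(C)c(C(=O)O)c23)c1`, gives 57500 nM, the only number among the three.

Compound 2 differs from compound 1 by hydrogen in place of methyl on an aromatic carbon. The step that the two limits leave unreadable from compound 1 to compound 2 cannot be sized because of the limit of > 1000000 nM in this assay, at which 2 of the 3 values shown sit. How the core of compound 3 differs from that of compound 1 is not broken down here.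

Compound 4, `Cc1oc2ncnc(Nc3ccccc3)c2c1C(=O)O`, has not been measured. It differs from compound 3 by hydrogen in place of methyl on an aromatic carbon. Going by the values given here, this is the same kind of change as the one from compound 1 to compound 2, but not the same: in compound 1 the methyl sits para to a large group, in compound 3 meta to a large group. Since the measured step gives no size, the expected step from compound 3 to compound 4 in this assay, a 1.2-fold higher number from compound 3 to compound 4 (0.09 log units; within the scatter), is taken as small and rests only on compound 3 at 57500 nM. Compound 4 is therefore estimated at 70000 nM, expected to lie between 20000 nM and 300000 nM.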

Compound 4, half-maximal inhibitory concentration: 246000 nM
Beside the measured number, compound 4's estimate is 3.5-fold (0.55 log units) below it; measured number inside the range.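

In this assay, replacing 3-methylphenyl with phenyl gives a 4.3-fold higher number from compound 3 to compound 4 (0.63 log units; beyond the scatter), so on this core the methyl goes with the lower number, which means stronger inhibition, though the effect is modest. The same kind of change on the other core, from compound 1 to compound 2, cannot be read, so this one pair does not show whether the step carries over to that core, either in size or in direction. That other step stays unread because both of its compounds give a limit of the assay and not a number: the limit of > 1000000 nM in this assay, at which 2 of the 4 values shown sit.

The compounds shown leave open what other groups would do in the place of this methyl on the six-membered ring, such as a methoxy group, a chlorine atom or an amine. They also leave open whether a carboxylic acid in place of the ethyl ester on the core of compound 1 would bring its values off the limit and make the comparison between the cores readable.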